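A few compounds are considered here, and "the series" means these few. Any claim that something is new, unique, unknown or untested is made for them only; others in the source may bear on it.

Measured compounds: compound 1 `C[C@@H](Nc1c(C(=O)NCc2ccc(F)cc2)nc(Br)c2cccnc12)c1ccccc1`, "not determined" (no result reported); compound 2 `NCCCNc1c(C(=O)NCc2ccc(F)cc2)nc(Br)c2cccnc12`, 6000 nM; compound 3 `N[C@H]1CC[C@H](Nc2c(C(=O)NCc3ccc(F)cc3)nc(Br)c3cccnc23)CC1`, 2000 nM.

In a functional assay on MCF7 cells (Homo sapiens) for cytotoxicity, read by MTT assay, with a stated time of 72 h (on this read-out higher numbers stand for weaker inhibition and lower numbers for stronger inhibition), compound 2 gives 6000 nM, and compound 3 gives 2000 nM. Compound 3 therefore holds the lowest of the two numbers reported; its nearest neighbour is compound 2, separated by a 3.0-fold lower number from compound 2 to compound 3 (0.48 log units; beyond the scatter). Compound 1 carries "not determined" (no result reported) in this assay.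

Compound 4 `O=C(NCc1ccc(F)cc1)c1nc(Br)c2cccnc2c1N1CCNCC1` differs from compound 3 in one place: piperazin-1-yl in place of (4-aminocyclohexyl)amino on an aromatic carbon. Going by the values given here, the only measured step, a 3.0-fold lower number from compound 2 to compound 3 (0.48 log units; beyond the scatter), concerns a different exchange, a chain for a carbocycle on the same nitrogen, and so bears on the present step only loosely. Among the compounds with values here, no measured pair shows a ring nitrogen joined directly to the aromatic carbon, as in compound 4. Within the data shown here, with one donor fewer and no precedent among the measured compounds, the step from compound 3 to compound 4 is expected to be small, if anything towards a higher number, and is estimated as a 1.5-fold higher number from compound 3 to compound 4 (0.18 log units; within the scatter). Compound 4 is thus expected to give about 3000 nM, within a range from 1000 nM to 12000 nM.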

Compound 4, half-maximal inhibitory concentration: 7000 nM
Estimate against measurement, compound 4: 2.3-fold (0.37 log units) below; low and high end bracket the measured number.
By their numbers in this assay, from the lowest: compound 3; then compounds 2 and 4 (each within the scatter of the next).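

In this assay the piperazin-1-yl group in place of (4-aminocyclohexyl)amino on this aromatic carbon gives a 3.5-fold higher number from compound 3 to compound 4 (0.54 log units; beyond the scatter) and so shows that the lower number of compound 3 does not extend to every six-membered non-aromatic ring at this position. Against the open chain of compound 2, the same group gives a 1.2-fold higher number from compound 2 to compound 4 (0.07 log units; within the scatter) and leaves compounds 2 and 4 indistinguishable, so among these compounds a ring in itself does not set compound 3 apart. Nothing measured here explains the difference between compound 3 and compound 4.

Going by these compounds, whether an aminopiperidine or a morpholine ring on this carbon would behave like compound 3 or compound 4 remains open. So does the part played by the defined stereocentres of compound 3, since its other stereoisomer is not among the compounds shown.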